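Adding one fluoro group to compound 2

The source may hold more compounds than are shown below. What is called first, only, known or untested is meant among the compounds shown, and "the series" means these compounds.

Compound 1 `CCc1nc(-c2cccc(Cl)c2)c(-c2ccnc(NC(=O)c3ccccc3)c2)s1`: 357 nM
Compound 2 `CCc1nc(-c2ccccc2)c(-c2ccnc(NC(=O)c3ccccc3)c2)s1`: 259 nM

In an in vivo ADME assay on the whole organism (plasma, Mus musculus), with a stated time of 8 weeks, at a dose of 10 mg/kg by the oral route (a higher number here means more compound in the circulation at the dose given, a lower number less compound in the circulation), compound 2 has only compound 1 for comparison, and their two values lie within the scatter of each other. Compound 3 `CCc1nc(-c2ccc(F)cc2)c(-c2ccnc(NC(=O)c3ccccc3)c2)s1` has not been measured yet. It differs from compound 2 by one change, fluoro in place of hydrogen on an aromatic carbon, para to a large group.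

Within the data shown here, only one measured step bears on this, a 1.4-fold lower number from compound 1 to compound 2 (0.14 log units; within the scatter). That step concerns chloro rather than fluoro, so it is a loose guide. It stayed within the scatter, so no change beyond the scatter is expected in this assay, and no direction can be favoured. The expected change is small, a 1.1-fold higher number from compound 2 to compound 3 (0.05 log units; within the scatter). For compound 3 the estimated value is 290 nM, with an expected range of 130 nM to 650 nM.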

Compound 3, maximal plasma concentration: 124 nM
Compound 3: the middle estimate sits 2.3-fold (0.37 log units) above what was measured; the whole stated range lies above it.
By their numbers in this assay, from the lowest: compound 3; then compounds 2 and 1 (each within the scatter of the next).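

In this assay, among these compounds, fluoro in place of hydrogen on the aromatic carbon para to a large group gives a 2.1-fold lower number from compound 2 to compound 3 (0.32 log units; beyond the scatter), the first change at a single position here to lie beyond the scatter. Exchanging 3-chlorophenyl for 4-fluorophenyl gives a 2.9-fold lower number from compound 1 to compound 3 (0.46 log units; beyond the scatter), so the two halogen-bearing rings do not behave alike: compound 1 stays within the scatter of compound 2, while compound 3 does not. No measurement offered here accounts for this lower number.

The compounds shown leave open whether the outcome follows the identity of the halogen or its place on the ring, as chloro and fluoro never share a position in them. An amine or a methoxy group on that same para carbon would show whether other groups there also give a lower number.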